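A new group on the nitrogen of compound 2

The source may report more compounds than this note shows. Statements on the series, on what has been measured and on what is new or still open speak of the compounds shown alone.

Compound 1 `COc1ccc(-c2c(Nc3cc(OC)c(OC)c(OC)c3)c3ccccc3oc2=O)cc1`: 77300 nM
Compound 2 `COc1ccc(-c2c(Nc3ccc(C)c(O)c3)c3ccccc3oc2=O)cc1`: 10200 nM

In a functional assay on HepG2 cells (Homo sapiens) for antiproliferative activity, read by MTT assay, with a stated time of 48 h (a lower number here means a stronger inhibitor, a higher number a weaker inhibitor), compound 2 gives 10200 nM, the lower of the two numbers, and compound 1 gives 77300 nM. The gap between these two values lies beyond the scatter. Compound 3 `COc1ccc(-c2c(Nc3ccc(NC(C)=O)cc3)c3ccccc3oc2=O)cc1` carries 4-acetamidophenyl in place of 3-hydroxy-4-methylphenyl on a nitrogen on an aromatic ring. Within the data shown here, no measured step covers such a change, so the expectation rests only on these two values. A modest move to a higher number in this assay is expected, with the estimated step of a 2.5-fold higher number from compound 2 to compound 3 (0.39 log units; beyond the scatter). The estimated value for compound 3 is 25000 nM, in a range from 7000 nM to 80000 nM.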

Compound 3, half-maximal inhibitory concentration: > 100000 nM
Compound 3 ended at the assay's limit; the forecaster's own chance of this, stated with the estimate: 10%; middle value at least 4.0-fold (0.60 log units) from the limit.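

In this assay, 4-acetamidophenyl in place of 3-hydroxy-4-methylphenyl on a nitrogen on an aromatic ring brings an at least 9.8-fold higher number from compound 2 to compound 3 (0.99 log units; beyond the scatter), showing that an amide-bearing ring at this place can carry the read-out to the top of the measurable range. Compound 3 gives only a limit of the assay, not a number, so the step is a lower bound: the limit of > 100000 nM in this assay, at which 1 of the 3 values shown sits.

On these data alone, whether the step follows from losing the hydroxy and methyl groups or from gaining the acetamido group stays open. So does how a ring bearing a simple amine or a carboxylic acid would read here.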